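The source may report more compounds than this note shows. Statements on the series, on what has been measured and on what is new or still open speak of the compounds shown alone.

Working notes on the series in a functional assay on A549 cells (Homo sapiens) for cytotoxicity, read by MTT assay, with a stated time of 6 days; a lower number here means that less compound is needed, a higher number that more compound is needed for the effect.

Compound 1, `COC(=O)c1c(-c2ccc(OCc3ccccc3)cc2)oc2ccccc2c1=O`, gives a reading in this assay that is only a limit of the measurement: > 25 ug/mL. Compound 2, `COC(=O)c1c(-c2ccc(OCc3ccccc3)cc2)oc2ccc(OC)cc2c1=O`, gives 22.1 ug/mL in this assay. The change between them is methoxy in place of hydrogen on an aromatic carbon, and it yields an at least 1.1-fold lower number from compound 1 to compound 2 (0.05 log units; that floor lies within the scatter); because of the limit of > 25 ug/mL in this assay, at which 2 of the 3 values shown sit, the size of that step is known only as a floor.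

Compound 3, `COc1ccc2c(=O)cc(-c3cc(OC)c(OC)c(OC)c3)oc2c1`, also gives a reading that is only a limit of this assay: > 25 ug/mL. How the core of compound 3 differs from the core of compound 1 is not broken down here.

Compound 4, `COc1cc(-c2cc(=O)c3ccc(OC)c(OC)c3o2)cc(OC)c1OC`, has not yet been measured in this assay. It differs from compound 3 by methoxy in place of hydrogen on an aromatic carbon. This is the same kind of change as that from compound 1 to compound 2, though the surroundings of the place are not identical: in compound 2 the entering group sits meta to a fused ring and para to a fused ring, whereas in compound 4 it sits ortho to a fused ring, ortho to a methoxy group and meta to a fused ring.

The earlier step supplies only a floor and lies within the scatter, so for compound 4 the step is expected to be a step that the limit leaves unreadable from compound 3 to compound 4, resting on compound 1 and compound 2 together with the limit of compound 3 at > 25 ug/mL. Compound 4 is accordingly estimated at 28 ug/mL, between 14 ug/mL and 60 ug/mL, with a real chance that this assay again reports only a limit.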

Compound 4, concentration for half-maximal effect: > 25 ug/mL
Compound 4: a limit, no number; the forecaster's own chance of this, stated with the estimate: 60%; the middle value is on the limit's open side.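

Compound 4, like compound 3, gives only a limit in this assay, so no step can be read from compound 3 to compound 4, because both readings sit at the same limit: the limit of > 25 ug/mL in this assay, at which 3 of the 4 values shown sit.

The compounds shown leave open whether methoxy in place of hydrogen at this place changes the reading in this assay at all, and what numbers compound 3 and compound 4 would give.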